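Naphthalene replaces a phenyl-triazole on the shared benzoate core

This account rests on a few compounds, and the source may have more. Where it says the series, first, only, none or still open, it means among the compounds named here.

Measured compounds in an in vitro functional assay on HEK ts201 cells for antagonist activity at Neuronal acetylcholine receptor; alpha4/beta2 (Homo sapiens), read by fluorescence and calcium flux; on this read-out lower numbers stand for stronger inhibition and higher numbers for weaker inhibition:
- compound 1 `CC1(C)CC(=O)N(c2ccccc2C(=O)OCC2CCCN(CCCc3ccccc3)C2)C1=O`: 4900 nM
- compound 2 `O=C(OCC1CCCN(CCCc2ccccc2)C1)c1ccccc1-c1ccccc1`: 13500 nM; 13500 nM (2 entries) (two entries)
- compound 3 `O=C(OCC1CCCN(CCCc2ccccc2)C1)c1ccccc1-n1cc(-c2ccccc2)nn1`: 2820 nM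

Compound 3 has the lowest of the two single numbers, and compound 1 sits close to it; the step of a 1.7-fold lower number from compound 1 to compound 3 (0.24 log units; within the scatter) does not rise above the scatter of repeated measurement. Compound 2, which carries a plain phenyl at the same position, shows two identical entries, and its value lies clearly higher than that of compound 3.

Compound 4 `O=C(OCC1CCCN(CCCc2ccccc2)C1)c1ccccc1-c1cccc2ccccc12` is the next step: naphthalen-1-yl in place of 4-phenyl-1H-1,2,3-triazol-1-yl on an aromatic carbon. Within the data shown here, no measured step swaps a nitrogen-containing ring for a carbon-only ring at this position, so the only guide is that a plain phenyl (compound 2) and a phenyl-triazole (compound 3) both sit in the micromolar range. Compound 4 is therefore estimated to land between these two, probably somewhat above compound 3, giving an expected step of a 2.1-fold higher number from compound 3 to compound 4 (0.33 log units; beyond the scatter) in this assay. The estimate for compound 4 is 6000 nM, with a range from 2000 nM to 20000 nM.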

Compound 4, half-maximal inhibitory concentration: 11700 nM
Beside the measured number, compound 4's estimate is 2.0-fold (0.29 log units) below it; the measured number falls inside the stated range.
By their numbers in this assay, from the lowest: compounds 3 and 1 (each within the scatter of the next); then compound 4.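

In this assay the earlier step between the two nitrogen-containing groups stayed within the scatter, but this position now gives a step beyond it: naphthalen-1-yl, which has only carbon atoms, gives a 4.1-fold higher number from compound 3 to compound 4 (0.62 log units; beyond the scatter) and also a 2.4-fold higher number from compound 1 to compound 4 (0.38 log units; beyond the scatter) on the same aromatic carbon. The second group of carbon only gives a number of similar size, with compound 2 at 13500 nM; 13500 nM (2 entries) and compound 4 at 11700 nM in the same assay. No measurement here explains these differences.

The compounds shown leave open whether the nitrogen atoms of the departing groups matter or whether other features of those groups account for the steps. They also leave open what a small group such as an amine or a carboxylic acid would do on this aromatic carbon.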